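Amine Variation on a Diaryl Ether Series

A few compounds are considered here, and "the series" means these few. Any claim that something is new, unique, unknown or untested is made for them only; others in the source may bear on it.

For the measured compounds named here, compound 2 `COc1cc(Oc2cccc(Nc3ccccc3)c2)cc(OC)c1CNCc1ccc(Cl)cc1` gives the lower of the two numbers measured so far: in a functional assay on SW-620 cells (Homo sapiens) for inhibition, read by MTT assay, with a stated time of 72 h (on this read-out lower numbers stand for stronger inhibition and higher numbers for weaker inhibition), compound 2 gives 6340 nM. Its neighbour compound 1 `COc1cc(Oc2cccc(Nc3ccccc3)c2)cc(OC)c1CN[C@H](C)c1ccccc1` carries a 1-phenylethyl group on the same amine nitrogen, and in this assay compound 1 gives 18700 nM. Going by the values given here, the one measured step, a 2.9-fold lower number from compound 1 to compound 2 (0.47 log units; beyond the scatter), is modest and beyond the scatter.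

Compound 3 `CCN1CCN(Cc2c(OC)cc(Oc3cccc(Nc4ccccc4)c3)cc2OC)CC1` has not been measured. It differs from compound 2 by 4-ethylpiperazin-1-yl in place of (4-chlorobenzyl)amino on a saturated chain carbon bound to an aromatic carbon. Read one bond further out, the exchange is ((4-chlorobenzyl)amino)methyl to (4-ethylpiperazin-1-yl)methyl.

Only a 2.9-fold lower number from compound 1 to compound 2 (0.47 log units; beyond the scatter) touches the amine position, and it swapped one substituent for another while keeping an aromatic ring on the amine nitrogen; compound 3 has no aromatic ring in the entering group. That step gives no guide to direction here. With no closer comparison, no step beyond the scatter is expected in this assay from compound 2 to compound 3, and the range is kept wide. Compound 3 is therefore estimated at 9000 nM, with a range of 2500 nM to 35000 nM, meaning an expected step of a 1.4-fold higher number from compound 2 to compound 3 (0.15 log units; within the scatter).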

Compound 3, half-maximal inhibitory concentration: > 20000 nM
Compound 3 gave a limit, no number (the forecaster's own chance of this, stated with the estimate: 5%); middle value at least 2.2-fold (0.34 log units) away from the limit.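

In this assay the reading for compound 3 is a limit of the assay and not a number: the limit of > 20000 nM in this assay, at which 1 of the 3 values shown sits. This is the first group shown at this place without an aromatic ring, and 4-ethylpiperazin-1-yl also carries no hydrogen-bond donor, unlike (4-chlorobenzyl)amino; the exchange gives an at least 3.1-fold higher number from compound 2 to compound 3 (0.49 log units; beyond the scatter), so this group does not hold the level of compound 2. Against (1-phenylethyl)amino the record gives only an at least 1.0-fold higher number from compound 1 to compound 3 (0.02 log units; that floor lies within the scatter), so no order can be set between those two compounds, and the (4-chlorobenzyl)amino group of compound 2 alone stands apart, with steps beyond the scatter to both others.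

The compounds shown do not separate the loss of the aromatic ring from the loss of the amine hydrogen: a 4-benzylpiperazin-1-yl group would keep the ring without the hydrogen, and a plain ethylamino group would keep the hydrogen without the ring. Also open, going by these compounds, is what the chlorine contributes, which a plain benzylamino group at the same place would address.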